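The compounds below may be only part of what the source reports. "The series", "measured", "known", "first", "only" and "open" are said of these compounds alone.

Of the compounds shown here, three sharing one core have been measured in a physicochemical assay for solubility, read by HPLC, with a stated time of 24 h; a lower number here means a less soluble compound, a higher number a more soluble compound. Compound 1 `COC(=O)CC1CCN(C[C@H]2CN(c3ccc(-n4cc(-c5ccccn5)cn4)c(F)c3)C(=O)O2)CC1` gives 92100 nM. Compound 2 `COC[C@H]1CN(c2ccc(-n3cc(-c4ccccn4)cn3)c(F)c2)C(=O)O1` gives 36200 nM, and compound 3 `O=CNC[C@H]1CN(c2ccc(-n3cc(-c4ccccn4)cn3)c(F)c2)C(=O)O1` gives 217000 nM, the highest of the three numbers. The steps between them were a 2.5-fold lower number from compound 1 to compound 2 (0.41 log units; beyond the scatter), a 2.4-fold higher number from compound 1 to compound 3 (0.37 log units; beyond the scatter) and a 6.0-fold higher number from compound 2 to compound 3 (0.78 log units; beyond the scatter). Compound 4 `O=C1O[C@@H](CNC(=O)C(F)(F)F)CN1c1ccc(-n2cc(-c3ccccn3)cn2)c(F)c1` differs from compound 3 by trifluoromethyl in place of hydrogen on a carbonyl carbon. No measured step alters that carbonyl carbon; the three steps shown all change the group on the saturated chain carbon and were modest in size, so the step of a 2.2-fold lower number from compound 3 to compound 4 (0.34 log units; beyond the scatter) is expected to be of similar modest size, in the lower direction. Compound 4 is therefore expected to give 100000 nM, within a range from 40000 nM to 250000 nM.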

Compound 4, solubility: 114000 nM
Compound 4: the middle estimate sits 1.1-fold (0.06 log units) below what was measured, and the stated range covers the measured number.
By their numbers in this assay, from the lowest: compound 2; then compounds 1, 4 and 3 (each within the scatter of the next, the first and the last beyond it).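

In this assay, this is the first change shown at the carbonyl carbon, and replacing hydrogen with trifluoromethyl there gives a step that stays within the scatter (a 1.9-fold lower number from compound 3 to compound 4 (0.28 log units; within the scatter)). The ((trifluoromethyl)carbonyl)amino group also sits within the scatter of the 4-((methoxycarbonyl)methyl)piperidin-1-yl group (a 1.2-fold higher number from compound 1 to compound 4 (0.09 log units; within the scatter)), but remains beyond it from methoxy (a 3.1-fold higher number from compound 2 to compound 4 (0.50 log units; beyond the scatter)). Nothing given here explains these numbers. Still open, from the compounds shown here alone, is whether a methyl or an amine on that carbonyl carbon would also stay within the scatter of compound 3.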